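A few compounds are considered here, and "the series" means these few. Any claim that something is new, unique, unknown or untested is made for them only; others in the source may bear on it.

compound 1 `CC(C)Cn1nc(C(=O)N[C@H]2COc3ccccc3N(C)C2=S)nc1Cc1ccccc1` - 1230 nM
compound 2 `CN1C(=S)[C@@H](NC(=O)c2nc(Cc3ccccc3)n(C3COC3)n2)COc2ccccc21` - 916 nM

In a functional assay on HT-29 cells (Homo sapiens) for inhibition, read by luminescence and CellTiter-Glo, with a stated time of 24 h (a lower number here means that less compound is needed, a higher number that more compound is needed for the effect), compound 2 gives 916 nM and stands level, within the scatter, with compound 1 at 1230 nM in the same measurement. For the measured compounds named here, compound 3 `CN1C(=S)[C@@H](NC(=O)c2nc(Cc3ccccc3)n(C3CCNC3)n2)COc2ccccc21` has pyrrolidin-3-yl in place of oxetan-3-yl on an aromatic nitrogen as its only change. Going by the values given here, the one measured step at that nitrogen, a 1.3-fold lower number from compound 1 to compound 2 (0.13 log units; within the scatter), lies within the scatter. Among the compounds with values here, no compound with pyrrolidin-3-yl has been measured, so the range stays wide. The expected step is a 1.1-fold higher number from compound 2 to compound 3 (0.04 log units; within the scatter) and no shift beyond the scatter is expected in this assay here. For compound 3 the estimate is 1000 nM with an expected range from 350 nM to 3000 nM in this measurement.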

Compound 3, half-maximal effective concentration: 1070 nM
Beside the measured number, compound 3's estimate is 1.1-fold (0.03 log units) below it; the range from low to high includes it.
By their numbers in this assay, from the lowest: compounds 2, 3 and 1 (each within the scatter of the next).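

In this assay, pyrrolidin-3-yl on this aromatic nitrogen gives a 1.2-fold higher number from compound 2 to compound 3 (0.07 log units; within the scatter), and against isobutyl it gives a 1.1-fold lower number from compound 1 to compound 3 (0.06 log units; within the scatter). So far, this position accepts a ring with a hydrogen-bond donor, in place of oxetan-3-yl with none, without a shift beyond the scatter. No measured evidence bears on this result.

Still open, on these data alone, is whether any group at this nitrogen moves the number beyond the scatter. A carboxylic acid or a longer chain ending in an amine would test this.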